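The compounds below may be only part of what the source reports. "The series", "measured", "known", "first", "only" and "open" are said of these compounds alone.

The compounds here differ only in the group on a carbonyl carbon. In a functional assay on HL-60 cells (Homo sapiens) for antiproliferative activity, read by MTT assay, with a stated time of 48 h (on this read-out lower numbers stand for stronger inhibition and higher numbers for weaker inhibition), compound 1 `CC(=O)O[C@@H]1/C=C/[C@@](C)(CCC=C(C)C)C/C=C(/CO)C(=O)/C=C/[C@@]1(C)O` gives 5050 nM as its reading, and compound 2 `CC(C)=CCC[C@]1(C)/C=C/[C@@H](OC(=O)C(C)C)[C@](C)(O)/C=C/C(=O)/C(CO)=C\C1` gives 4000 nM as its reading. These two numbers lie within the scatter of each other, and compound 2 cannot be ranked apart from compound 1.

Compound 3 `CCCC(=O)O[C@@H]1/C=C/[C@@](C)(CCC=C(C)C)C/C=C(/CO)C(=O)/C=C/[C@@]1(C)O` changes one group of compound 2, with propyl in place of isopropyl on a carbonyl carbon and the two have the same atoms, joined differently.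

Within the data shown here, the one measured step that bears on this is isopropyl in place of methyl on a carbonyl carbon, which gave a 1.3-fold lower number from compound 1 to compound 2 (0.10 log units; within the scatter) and stands as the only guide. Among the measured compounds shown here, no measured compound carries propyl at this place. With this single small step in hand, the expectation in this assay is no step beyond the scatter, and neither direction is favoured. The estimated change is a 1.1-fold higher number from compound 2 to compound 3 (0.05 log units; within the scatter) and it is expected to stay small. For compound 3 the expected value is 4500 nM with an estimated range from 2400 nM to 8500 nM in this assay.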

Compound 3, half-maximal inhibitory concentration: 4180 nM
Estimate against measurement, compound 3: 1.1-fold (0.03 log units) above; measured number inside the range.
By their numbers in this assay, from the lowest: compounds 2, 3 and 1 (each within the scatter of the next).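

Swapping isopropyl for propyl on this carbonyl carbon rearranges the same three carbons from a branched group into a straight one, and in this assay this gives a 1.0-fold higher number from compound 2 to compound 3 (0.02 log units; within the scatter), so the branching of this group has no readable effect on the number. Measured against the methyl of compound 1, the propyl group gives a 1.2-fold lower number from compound 1 to compound 3 (0.08 log units; within the scatter), and this step, like the isopropyl step before it, leaves the three groups unranked: across methyl, isopropyl and propyl, the number does not respond beyond the scatter. No measurement is available to explain why these readings stay so close together.

The compounds shown leave open whether a much longer chain such as octyl, or a phenyl ring, on this carbonyl carbon would finally produce a step beyond the scatter, since all three groups here are small and made only of saturated carbons. They also leave open what an amine carried on this group would do, and whether replacing the oxygen next to the carbonyl group with a nitrogen, giving an amide, would change the reading.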